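Replacing the amino group of compound 3 with hydrogen

This account rests on a few compounds, and the source may have more. Where it says the series, first, only, none or still open, it means among the compounds named here.

Four related compounds frame this question. In a functional assay on SW480 cells (Homo sapiens) for cytotoxicity, read by sulforhodamine B assay, with a stated time of 48 h (a higher number here means a weaker inhibitor, a lower number a stronger inhibitor), compound 3 (`COc1ccc(/C=C/C(=O)c2ccc(N)c(-c3ccc(F)cc3)c2)cc1OC`) gives 6640 nM as its reading, and compound 1 (`COc1ccc(/C=C/C(=O)c2cccc(-c3ccc(F)cc3)c2)cc1`) gives 8350 nM as its reading. Within the data shown here, these two numbers lie within the usual scatter of each other, so compound 3 stands level with the only other number available. Compound 2 (`COc1ccc(/C=C/C(=O)c2cccc(Br)c2)cc1OC`) is recorded as "not determined" (no result reported) and so adds no number to the comparison.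

Compound 4 (`COc1ccc(/C=C/C(=O)c2cccc(-c3ccc(F)cc3)c2)cc1OC`) has not yet been measured. It differs from compound 3 by one change: hydrogen in place of amino on an aromatic carbon, ortho to a 4-fluorophenyl group and para to a large group (hydrogen in place of amino on an aromatic carbon). Among the measured compounds shown here, no two measured compounds differ in one place only, so the data give no direct size for this change. For the measured compounds named here, compound 1 at 8350 nM and compound 3 at 6640 nM are the only guide, and they sit within the scatter of each other. The estimated move a 1.1-fold higher number from compound 3 to compound 4 (0.05 log units; within the scatter) in this assay is therefore expected to stay within the scatter, with no firm direction. The estimate for compound 4 is 7500 nM, expected to fall between 3500 nM and 16000 nM when measured.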

Compound 4, half-maximal inhibitory concentration: 6490 nM
Compound 4: the middle estimate sits 1.2-fold (0.06 log units) above what was measured; low and high end bracket the measured number.
By their numbers in this assay, from the lowest: compounds 4, 3 and 1 (each within the scatter of the next).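

Among these compounds, the pair of compound 3 and compound 4 gives the first direct reading at this position: in this assay, hydrogen in place of amino on an aromatic carbon, ortho to a 4-fluorophenyl group and para to a large group, comes to a 1.0-fold lower number from compound 3 to compound 4 (0.01 log units; within the scatter). At this level of resolution, the amino group and hydrogen therefore cannot be told apart on this carbon. Compound 4 also links to compound 1 through a second single change, methoxy in place of hydrogen on an aromatic carbon, which comes to a 1.3-fold lower number from compound 1 to compound 4 (0.11 log units; within the scatter), so neither change separates from the scatter, and nothing available explains these results.

The compounds shown leave open whether a different group on the same carbon, such as a carboxylic acid, a dimethylamino group or an acetamide, would stand apart from the amino group and hydrogen in this cell assay. The step between compound 2 and compound 4, with bromine in place of the 4-fluorophenyl group, cannot be read, leaving the contribution of that group undefined.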